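Chain Extension on the Amine Tail of Compound 3

The compounds below may be only part of what the source reports. "The series", "measured", "known", "first", "only" and "open" are said of these compounds alone.

Measured so far:
compound 1 `CC(C)(C)OC(=O)NCCNC(=O)CN1CN(c2ccccc2)C2(CCN(C(=O)c3ccc(C(C)(C)C)cc3)CC2)C1=O` 10900 nM
compound 2 `CC1(C)CC(OC(=O)CN2CN(c3ccccc3)C3(CCN(C(=O)c4ccc(C(C)(C)C)cc4)CC3)C2=O)CC(C)(C)N1` 1300 nM
compound 3 `CC(C)(C)c1ccc(C(=O)N2CCC3(CC2)C(=O)N(CC(=O)NCCCN)CN3c2ccccc2)cc1` 4200 nM

In an assay on HEK293 cells for displacement of a labelled ligand from NPC1-like intracellular cholesterol transporter 1 (Homo sapiens) (a lower number here means a stronger inhibitor, a higher number a weaker inhibitor), compound 3 stands second highest of the three numbers. Its nearest neighbour is compound 1, reached by a 2.6-fold lower number from compound 1 to compound 3 (0.41 log units; beyond the scatter); its furthest is compound 2, which lies a step away described by a 3.2-fold higher number from compound 2 to compound 3 (0.51 log units; beyond the scatter). Both steps are modest, and both involve the tail carried by the carbonyl carbon of the shared core.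

Compound 4 `CC(C)(C)c1ccc(C(=O)N2CCC3(CC2)C(=O)N(CC(=O)NCCCCN)CN3c2ccccc2)cc1` is not yet measured in this assay. It differs from compound 3 only in this: aminomethyl in place of amino on a saturated chain carbon, three bonds along the chain from an amide-type nitrogen. Among the measured compounds shown here, no measured step changes the chain length of an amine tail alone; the two steps from compound 3 alter the end group or replace the whole tail. Those steps moved the numbers by modest amounts, which suggests the tail region tolerates variation without large swings. A one-carbon extension is a smaller change than either measured step, so no step beyond the scatter is expected in this assay, in either direction.

Compound 4 is therefore expected to give about 4000 nM, estimated between 1800 nM and 9000 nM. This estimate implies a 1.1-fold lower number from compound 3 to compound 4 (0.02 log units; within the scatter).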

Compound 4, half-maximal inhibitory concentration: 14500 nM
Compound 4: the middle estimate sits 3.6-fold (0.56 log units) below what was measured; measured number above the stated range.
By their numbers in this assay, from the lowest: compound 2; then compound 3; then compounds 1 and 4 (each within the scatter of the next).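

In this assay, among the compounds shown here, a one-carbon extension of the free amine tail is not a silent change: a 3.5-fold higher number from compound 3 to compound 4 (0.54 log units; beyond the scatter), and this is the first step that isolates chain length at this position, three bonds along the chain from an amide-type nitrogen. The 4-aminobutyl tail also loses the separation that the 3-aminopropyl tail had from the tert-butoxycarbonyl-capped tail, since a 1.3-fold higher number from compound 1 to compound 4 (0.12 log units; within the scatter), so a free terminal amine alone does not set this tail apart from that capped one. For the compounds shown here, replacing the (2,2,6,6-tetramethylpiperidin-4-yl)oxy group on the carbonyl carbon with (4-aminobutyl)amino now gives the only large step: an 11-fold higher number from compound 2 to compound 4 (1.05 log units; beyond the scatter).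

Nothing available explains why one added carbon shifts the number this far. With only the 3-aminopropyl and 4-aminobutyl tails to compare directly, the series leaves open whether a free 2-aminoethyl tail or a longer 5-aminopentyl chain would continue this direction, and whether a carboxylic acid at the chain end would behave like the amine.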